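Replacing the benzoxazolylsulfanyl group in compound 1

The source may hold more compounds than are shown below. What is called first, only, known or untested is meant among the compounds shown, and "the series" means these compounds.

Values in a functional assay on KYSE-450 cells (Homo sapiens) for inhibition, read by CCK-8 assay, with a stated time of 48 h; a higher number here means a weaker inhibitor, a lower number a stronger inhibitor:
- compound 1 `COc1ccc(CN(C(=O)CSc2nc3ccccc3o2)c2cc(OC)c(OC)c(OC)c2)cc1`: 840 nM
- compound 2 `COc1ccc(CN(C(=O)CSC(=S)N2CCN(Cc3ccc(C(C)(C)C)cc3)CC2)c2cc(OC)c(OC)c(OC)c2)cc1`: 2140 nM
- compound 3 `COc1ccc(CN(C(=O)CSC(=S)N2CCCc3cc(OC)ccc32)c2cc(OC)c(OC)c(OC)c2)cc1`: 5530 nM

Compound 1 stands lowest of the three, and so is the strongest inhibitor measured in this assay. Compound 4 `CCN1CCN(CC(=O)N(Cc2ccc(OC)cc2)c2cc(OC)c(OC)c(OC)c2)CC1` carries 4-ethylpiperazin-1-yl in place of (1,3-benzoxazol-2-yl)sulfanyl on a saturated chain carbon bound to a carbonyl carbon. Among the measured compounds shown here, no pair of measured compounds differs in one place only, so the size of this change has no direct precedent. Compound 1 at 840 nM already holds the lowest number, so a rise beyond the scatter is expected, towards weaker inhibition. The estimated change is a 3.6-fold higher number from compound 1 to compound 4 (0.55 log units; beyond the scatter). For compound 4 the expected value is 3000 nM, within an estimated range of 800 nM to 12000 nM.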

Compound 4, half-maximal inhibitory concentration: 16100 nM
Compound 4: middle estimate off by 5.4-fold (0.73 log units), on the low side; measured number above the stated range.
By their numbers in this assay, from the lowest: compound 1; then compound 2; then compound 3; then compound 4.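

In this assay, among the compounds shown here, the change to 4-ethylpiperazin-1-yl from (1,3-benzoxazol-2-yl)sulfanyl on a saturated chain carbon bound to a carbonyl carbon gives a 19-fold higher number from compound 1 to compound 4 (1.28 log units; beyond the scatter) and is the first one-place step read. It shows that inhibition depends strongly on the group at this position, at least for this pair. Still open, going by these compounds, is whether the loss follows from removing the sulfur link or the fused aromatic rings, which a (1,3-benzoxazol-2-yl)amino group would help separate. Nothing shown here accounts for the loss.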